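Acetyl to benzoyl on the indole acrylonitrile/acryloyl series

A few compounds are considered here, and "the series" means these few. Any claim that something is new, unique, unknown or untested is made for them only; others in the source may bear on it.

Measured compounds in a functional assay on MDA-MB-468 cells (Homo sapiens) for inhibition, read by sulforhodamine B assay, with a stated time of 48 h; on this read-out lower numbers stand for stronger inhibition of growth and higher numbers for weaker inhibition of growth:
- compound 1, `COc1ccc(-c2[nH]c3ccccc3c2/C=C(\C#N)S(=O)(=O)c2ccccc2)cc1`: < 10 nM; this is a limit of the assay, not a number
- compound 2, `COc1ccc2[nH]c(-c3ccccc3)c(C=C(C#N)C#N)c2c1`: 2100 nM
- compound 3, `CC(=O)/C(=C\c1c(-c2ccccc2)[nH]c2ccccc12)S(=O)(=O)c1ccccc1`: 1700 nM

Compound 3 stands at the lowest of the two numbers given. Compound 2 gives 2100 nM, which lies within the usual scatter of compound 3, so the two cannot be ordered against each other. For compound 1 only a limit is available, (the limit of < 10 nM in this assay, at which 1 of the 3 values shown sits), and it is not compared as a number.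

Compound 4, `O=C(/C(=C\c1c(-c2ccccc2)[nH]c2ccccc12)S(=O)(=O)c1ccccc1)c1ccccc1`, is the next compound to be measured. It differs from compound 3 by phenyl in place of methyl on a carbonyl carbon; cut one bond further out, the change reads acetyl to benzoyl. For the measured compounds named here, no measured pair in the set carries this change, so its size in this assay cannot be read from the data and is a guess. The expectation is a step no larger than modest, more likely toward a lower number than a higher one, but a result inside the scatter would not surprise. Compound 4 is estimated at 900 nM, with a range from 200 nM to 4000 nM. The step this implies from compound 3 to compound 4 is expected to be a 1.9-fold lower number from compound 3 to compound 4 (0.28 log units; within the scatter).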

Compound 4, concentration for 50% growth inhibition: 4200 nM
Compound 4: middle estimate off by 4.7-fold (0.67 log units), on the low side; the whole stated range lies below it.
By their numbers in this assay, from the lowest: compounds 3, 2 and 4 (each within the scatter of the next, the first and the last beyond it). At a limit, below all of these: compound 1.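

In this assay, for the compounds shown here, the carbonyl carbon proves sensitive to what it carries: phenyl in place of methyl gives a 2.5-fold higher number from compound 3 to compound 4 (0.39 log units; beyond the scatter), the only step in the set that can be read at this position, and a modest one. The direction is toward weaker inhibition of growth, so at this position, on this core, the larger group with its six-membered aromatic ring is not tolerated as well as the single carbon of the methyl group, although two substituents are too few to make this a trend. Nothing in the data at hand accounts for this step.

With only methyl and phenyl on this carbonyl carbon, the data cannot separate the effect of the ring itself from that of the added carbon count, and an ethyl, an isopropyl or a cyclohexyl group would be needed to tell the two apart. Also open, from the compounds shown here alone, is how the position responds to a group that brings in a heteroatom, such as a dimethylamino group on the carbonyl carbon or a hydroxyl or carboxylic acid on the phenyl ring of the benzoyl group.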